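The source may hold more compounds than are shown below. What is called first, only, known or untested is meant among the compounds shown, and "the series" means these compounds.

Compound 1 `COc1ccc(C(C)C)cc1CN[C@H]1[C@H](C(C)(C)C)[C@@H](C(=O)O)N(C(=O)C2CCCCC2)[C@H]1c1ccccc1`, compound 2 `COc1ccc(C(C)(C)C)cc1CN[C@H]1[C@H](C(C)(C)C)[C@@H](C(=O)O)N(C(=O)C2CCCCC2)[C@H]1c1ccccc1` and compound 3 `COc1ncc(C(F)(F)F)cc1CN[C@H]1[C@H](C(C)(C)C)[C@@H](C(=O)O)N(C(=O)C2CCCCC2)[C@H]1c1ccccc1` share one core and differ only in the aromatic ring that hangs from the amine. In an assay on HBE cells for positive allosteric modulation of Cystic fibrosis transmembrane conductance regulator variant F508del (Homo sapiens) (a lower number here means that less compound is needed, a higher number that more compound is needed for the effect), compound 1 gives 188 nM, compound 2 gives 113 nM and compound 3 gives 210 nM, the highest of the three numbers, although all three sit within the scatter of one another. Compound 4 `COc1ncc(C2CCC2)cc1CN[C@H]1[C@H](C(C)(C)C)[C@@H](C(=O)O)N(C(=O)C2CCCCC2)[C@H]1c1ccccc1` carries cyclobutyl in place of trifluoromethyl on an aromatic carbon. Going by the values given here, the steps that bear on this change are a 1.1-fold higher number from compound 1 to compound 3 (0.05 log units; within the scatter), a 1.9-fold higher number from compound 2 to compound 3 (0.27 log units; within the scatter) and, for exchanging one group on that aromatic ring, a 1.7-fold lower number from compound 1 to compound 2 (0.22 log units; within the scatter), none of them beyond the scatter. Compound 4 is therefore expected to show no step beyond the scatter in this assay, a 1.2-fold lower number from compound 3 to compound 4 (0.09 log units; within the scatter). The estimate for compound 4 is 170 nM, ranging from 70 nM to 420 nM.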

Compound 4, half-maximal effective concentration: 184 nM
For compound 4 the middle estimate is 1.1-fold (0.03 log units) below the measured one; measured number inside the range.
By their numbers in this assay, from the lowest: compounds 2, 4, 1 and 3 (each within the scatter of the next).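

On this aromatic carbon, para to a methoxy group, cyclobutyl, a ring of carbon only, takes the place of trifluoromethyl with no step beyond the scatter in this assay (a 1.1-fold lower number from compound 3 to compound 4 (0.06 log units; within the scatter)). Set against the two phenyl compounds, the new pyridine compound also stays within the scatter (a 1.6-fold higher number from compound 2 to compound 4 (0.21 log units; within the scatter); a 1.0-fold lower number from compound 1 to compound 4 (0.01 log units; within the scatter)). No measurement at hand bears on why these groups read alike. As far as these compounds go, whether an amine, a carboxylic acid or a longer carbon chain on this aromatic carbon would also stay within the scatter remains open.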